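This account rests on a few compounds, and the source may have more. Where it says the series, first, only, none or still open, it means among the compounds named here.

Compound 1 `C1=C(c2cncc(Oc3ccccc3)c2)CC2CNCC1C2` gives 52%
Compound 2 `C1=C(c2ccc(-c3ccccc3)nc2)CC2CNCC1C2` gives 19%
Compound 3 `CN1C[C@@H]2C=C(c3cccnc3)C[C@@H](C2)C1` gives 53%

All three numbers come from an in vitro functional assay on SH-EP1 cells for agonist activity at Neuronal acetylcholine receptor; alpha4/beta2 (Homo sapiens), read by FLIPR and calcium flux; a higher number here means a larger maximal response, a lower number a smaller maximal response. Compound 1 holds the second highest of these three values. Closest to it is compound 3, whose value lies within the scatter of it, so the two cannot be told apart. Furthest from it is compound 2, whose value lies well beyond the scatter on the low side. Compound 4 `CC(C)Oc1cncc(C2=CC3CNCC(C2)C3)c1` has not yet been measured. It differs from compound 1 in one place: isopropyl in place of phenyl on an oxygen on an aromatic ring. Within the data shown here, no measured pair shows this exact change, so the size of the step can only be guessed from the spread seen so far. For compound 4 the estimate is 50%, between 28% and 72%, and the step of a number 2 percentage points lower from compound 1 to compound 4 (within the scatter) is expected to stay within the usual scatter.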

Compound 4, largest response reached (reported as percent of maximum), in percent of the reference or control that the assay uses: 75%
Compound 4: middle estimate off by 25 percentage points, on the low side; the whole stated range lies below it.
By their numbers in this assay, from the lowest: compound 2; then compounds 1 and 3 (each within the scatter of the next); then compound 4.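

Isopropyl in place of phenyl on an oxygen on an aromatic ring gives a number 23 percentage points higher from compound 1 to compound 4 (beyond the scatter) in this assay and so shows that this place responds to the group it carries. The phenyl ring is therefore not required for a sizeable maximal response on the core of compound 1. Nothing at hand explains the rise.

The two groups differ both in having a ring and in carbon count, so the compounds shown do not separate these. As far as these compounds go, whether a cyclopropyl, an ethyl or a longer chain on the same oxygen behaves like isopropyl stays open.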